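Chlorine position on the styryl arm of a sulfonate ester

This account rests on a few compounds, and the source may have more. Where it says the series, first, only, none or still open, it means among the compounds named here.

Measured so far:
compound 1 `COc1ccc(OS(=O)(=O)/C=C/c2ccccc2Cl)cc1`: 237 nM
compound 2 `COc1cccc(OS(=O)(=O)/C=C/c2ccc(Cl)cc2)c1`: 1780 nM

Two compounds have been run in an assay on U2OS cells for activation of nuclear factor erythroid 2-related factor 2 (Homo sapiens), read by chemiluminescence, with a stated time of 6 h; on this read-out higher numbers stand for an effect only at larger amounts of compound and lower numbers for an effect already at smaller amounts. Going by the values given here, compound 1 `COc1ccc(OS(=O)(=O)/C=C/c2ccccc2Cl)cc1` gives 237 nM, the lower of the two numbers and well beyond the scatter from its only neighbour. Compound 2 `COc1cccc(OS(=O)(=O)/C=C/c2ccc(Cl)cc2)c1` gives 1780 nM; it differs from compound 1 in more than one place, so the gap cannot be tied to a single change.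

Compound 3 `COc1ccc(OS(=O)(=O)/C=C/c2ccc(Cl)cc2)cc1` has not been measured. It differs from compound 1 in one place: 4-chlorophenyl in place of 2-chlorophenyl on a double-bonded chain carbon bound to a double-bonded chain carbon. Compound 3 carries the 4-chlorophenyl group also found in compound 2, while keeping the rest of compound 1 unchanged.

Among the compounds with values here, since no single-change step is on record, the direction can only be inferred from the weaker compound 2, which carries the same 4-chlorophenyl group. A moderate rise in the number is expected, by a 2.7-fold higher number from compound 1 to compound 3 (0.44 log units; beyond the scatter), beyond the scatter but not as far as compound 2. Compound 3 is therefore estimated at 650 nM, with a range of 200 nM to 2100 nM.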

Compound 3, half-maximal effective concentration: 1160 nM
The estimate for compound 3 lay 1.8-fold (0.25 log units) below the measured number; the measured number falls inside the stated range.
By their numbers in this assay, from the lowest: compound 1; then compounds 3 and 2 (each within the scatter of the next).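

In this assay, 4-chlorophenyl in place of 2-chlorophenyl on a double-bonded chain carbon bound to a double-bonded chain carbon gives a 4.9-fold higher number from compound 1 to compound 3 (0.69 log units; beyond the scatter), with the same atoms joined differently. Going by these compounds alone, this is the first step tied to a single change: the earlier gap between compound 1 and compound 2 involved more than one difference, whereas this one shows that the place of the chlorine alone is enough to move the number beyond the scatter. Compound 3 at 1160 nM and compound 2 at 1780 nM lie within the scatter of each other, so among the compounds carrying 4-chlorophenyl, where the methoxy group is attached shows no separable effect.

No supporting measurement bears on why the place of the chlorine matters here. As far as these compounds go, it remains open whether a bromine or a methyl group in place of the chlorine of 2-chlorophenyl would keep the number of compound 1 , and whether an ethoxy group, an amine or a carboxylic acid could stand in place of the methoxy group.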